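The compounds below may be only part of what the source reports. "The series", "measured", "known", "first", "only" and "open" are said of these compounds alone.

Three compounds were measured in a functional assay on MCF7 cells (Homo sapiens) for cytotoxicity, read by MTT assay, with a stated time of 72 h, tested at 10 uM; a higher number here means more inhibition of growth at the concentration tested, a lower number less inhibition of growth:

compound 1, `N/C(=N\NC(=S)N1CCCCCC1)c1ccccn1`, 62.2%
compound 2, `Cc1ccnc(/C(N)=N/NC(=S)N2CCN(c3ccccn3)CC2)c1`, 32.1%
compound 3, `Cc1cccc(/C(N)=N/NC(=S)N2CCCCCC2)n1`, 21.5%

Compound 3 and compound 1 share a core and differ in a single place: hydrogen in place of methyl on an aromatic carbon. The step that goes with this change is a number 40.7 percentage points higher from compound 3 to compound 1 (beyond the scatter).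

Compound 4, `N/C(=N\NC(=S)N1CCN(c2ccccn2)CC1)c1ccccn1`, has not yet been measured. It stands to compound 2 as compound 1 stands to compound 3: hydrogen in place of methyl on an aromatic carbon. The two changes are the same kind of change, though not the same. In compound 3 the methyl sits next to the ring nitrogen, meta to a large group; in compound 2 it sits meta to a large group, opposite the ring nitrogen. The cores of compound 2 and compound 3 differ as well, and that difference is not broken down here. For the measured compounds named here, their values show only that compound 2 stands higher than compound 3 in this assay, a gap that lies beyond the scatter.

Given that compound 3 and compound 1 showed a number 40.7 percentage points higher from compound 3 to compound 1 (beyond the scatter), compound 4 is expected to stand above compound 2, but the methyl leaves a different place on the ring and the core is not the same, so a smaller step is expected. For compound 4 the expected step is a number 17.9 percentage points higher from compound 2 to compound 4 (beyond the scatter). Compound 4 is estimated at 50%, within a range from 28% to 72%.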

Compound 4, percent growth inhibition at one concentration: 46.4%
Estimate against measurement, compound 4: 3.6 percentage points above; the range from low to high includes it.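

Going from 4-methylpyridin-2-yl to pyridin-2-yl, this assay gives a number 14.3 percentage points higher from compound 2 to compound 4 (beyond the scatter). Hydrogen in place of methyl on an aromatic carbon thus raises the number on both cores shown, so the direction of the step carries over between these two pairs, while its size does not: the same change on two cores in this assay, a number 40.7 percentage points higher (beyond the scatter) from compound 3 to compound 1 and a number 14.3 percentage points higher (beyond the scatter) from compound 2 to compound 4, 26.4 percentage points apart, beyond the scatter of two such steps. The two pairs do not show what sets the sizes apart, as they differ both in the core and in the place the methyl leaves on the ring, and nothing here separates these two differences; they give a shared direction for these two cores only, not a rule for other cores in the series.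

The compounds shown leave open what a single core would give with the methyl at each of the two places on the ring, which would take the core out of the comparison. They also leave open what an ethyl group, a methoxy group or an amine would give on that same aromatic carbon, and whether the step from such a group to hydrogen would follow the one seen for methyl.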